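Fluoro added to the distal phenyl of the thiazole series

The source may report more compounds than this note shows. Statements on the series, on what has been measured and on what is new or still open speak of the compounds shown alone.

Two compounds of the series have been run in an assay on CHO cells for agonist activity at Free fatty acid receptor 1 (Homo sapiens), read by FLIPR; a lower number here means that less compound is needed, a higher number that more compound is needed for the effect. Compound 1 (`O=C(O)COc1ccc(OCc2nnc(-c3ccccc3)s2)cc1F`) returns only a limit, > 10000 nM, and no number. Compound 2 (`Cc1nc(-c2ccccc2)sc1COc1ccc(S(=O)(=O)CC(=O)O)cc1`) gives 370 nM. Among the recorded values compound 2 thus holds the only actual number; the other entry is the limit of > 10000 nM in this assay, at which 1 of the 2 values shown sits. For the measured compounds named here, no two measured compounds differ in one place, so no measured step is available.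

Compound 3 (`Cc1nc(-c2ccc(F)cc2)sc1COc1ccc(S(=O)(=O)CC(=O)O)cc1`) is not yet measured. It departs from compound 2 by fluoro in place of hydrogen on an aromatic carbon, a fluoro in place of hydrogen on an aromatic carbon, so that the phenyl becomes 4-fluorophenyl. The step is expected to be small, a 1.2-fold lower number from compound 2 to compound 3 (0.09 log units; within the scatter), most likely within the scatter of repeated measurements and without a clear direction. Compound 3 is accordingly estimated at 300 nM in this assay, with a range from 100 nM to 900 nM.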

Compound 3, half-maximal effective concentration: 253 nM
For compound 3 the middle estimate is 1.2-fold (0.07 log units) above the measured one; the range from low to high includes it.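

In this assay the series now has its first measured step between compounds that differ in one place, and a 1.5-fold lower number from compound 2 to compound 3 (0.17 log units; within the scatter) lies within the scatter, so phenyl and 4-fluorophenyl cannot be told apart here. The aromatic carbon para to a large group therefore accepts a single fluoro with the effect retained, which neither earlier compound could show on its own. Nothing at hand bears on the cause of this step, and a step within the scatter offers little to explain.

On these data alone, whether this carbon accepts a larger or different group, such as methoxy, trifluoromethyl or an amine, remains open, as does whether fluoro on the other carbons of the same ring would behave alike. Compound 1 gives > 10000 nM, which is a limit of the assay, and it differs from compound 2 and compound 3 in more than one place, so it offers no reading on this position.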